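Branching the propyl chain: from compound 1 to compound 3

The source may hold more compounds than are shown below. What is called first, only, known or untested is meant among the compounds shown, and "the series" means these compounds.

Measured so far:
- compound 1 `CCCn1ncnc1-c1ccccc1NCC1=NCCN1`: 74%
- compound 2 `CC(C)n1nccc1-c1ccccc1NCC1=NCCN1`: 0%

Compound 1 stands at the top of these two numbers. In a functional assay with Alpha-1B adrenergic receptor (Homo sapiens) as the target, read by calcium flux (on this read-out higher numbers stand for larger maximal responses and lower numbers for smaller maximal responses), compound 1 gives 74%, while compound 2 gives 0%, a gap well beyond the usual scatter. Compound 2 differs from compound 1 in more than one place, so its value alone cannot say what any single change does.

Compound 3 `CC(C)n1ncnc1-c1ccccc1NCC1=NCCN1` has not been measured yet. It differs from compound 1 in one place only: isopropyl in place of propyl on an aromatic nitrogen. The change keeps the same atoms, joined differently, and no direct comparison of this kind exists among the measured compounds. The step is expected to be small to moderate in this assay, more likely downward than upward, with the estimate a number 19 percentage points lower from compound 1 to compound 3 (beyond the scatter). Compound 3 is therefore expected to give about 55%, within a range from 15% to 85%.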

Compound 3, largest response reached (reported as maximal response), in percent of the reference or control that the assay uses: 0%
Beside the measured number, compound 3's estimate is 55 percentage points above it; measured number below the stated range.
By their numbers in this assay, from the lowest: compounds 2 and 3 (each within the scatter of the next); then compound 1.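

In this assay, isopropyl in place of propyl on an aromatic nitrogen gives a number 74 percentage points lower from compound 1 to compound 3 (beyond the scatter), so at this position the maximal response depends on how the carbons of the chain are joined, not only on how many there are. Compound 2 could not show this, since it differs from compound 1 in more than one place, whereas this single change is enough on its own to leave compound 3 at 0%. Nothing measured here explains why the two chains behave so differently.

Open, from the compounds shown here alone, is how much branching this position allows: whether an ethyl, a butyl or a cyclopropyl group on the same nitrogen would keep the response of compound 1 or lose it. Also open, going by these compounds, is whether a chain carrying an amine would be tolerated there.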